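Trimethoxyphenyl ethers: step from compound 3 to compound 4

This account rests on a few compounds, and the source may have more. Where it says the series, first, only, none or still open, it means among the compounds named here.

Measured in a functional assay on LNCaP cells (Homo sapiens) for antiproliferative activity, read by WST assay, with a stated time of 3 days; on this read-out lower numbers stand for stronger inhibition and higher numbers for weaker inhibition:
- compound 1 `CCOc1c(-c2cc(OC)c(OC)c(OC)c2)oc2ccccc2c1=O`: 5400 nM
- compound 2 `CCCCCOc1c(-c2cc(OC)c(OC)c(OC)c2)oc2ccccc2c1=O`: 15400 nM
- compound 3 `CCCN(CCC)CCCCCOc1c(-c2cc(OC)c(OC)c(OC)c2)oc2ccccc2c1=O`: 7600 nM

Two steps place compound 3: a 1.4-fold higher number from compound 1 to compound 3 (0.15 log units; within the scatter), and a 2.0-fold lower number from compound 2 to compound 3 (0.31 log units; beyond the scatter). The change to compound 4 `CCCCCN(CCCCC)CCCOc1c(-c2cc(OC)c(OC)c(OC)c2)oc2ccccc2c1=O` is dipentylamino in place of 2-(dipropylamino)ethyl on a saturated chain carbon, three bonds along the chain from an oxygen on an aromatic ring. In words, dipentylamino stands in place of 2-(dipropylamino)ethyl on a saturated chain carbon, three bonds along the chain from an oxygen on an aromatic ring. Among the compounds with values here, no measured pair isolates this exchange, so the other steps serve only as a guide to size. The largest is a 2.9-fold higher number from compound 1 to compound 2 (0.46 log units; beyond the scatter), and the step that adds the dipropylamino group is a 2.0-fold lower number from compound 2 to compound 3 (0.31 log units; beyond the scatter). With steps this modest, no clear shift is expected in this assay, and the expected outcome is a 1.1-fold lower number from compound 3 to compound 4 (0.04 log units; within the scatter). For compound 4 the estimated value is 7000 nM, with an expected range of 3000 nM to 16000 nM.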

Compound 4, half-maximal inhibitory concentration: 5100 nM
Beside the measured number, compound 4's estimate is 1.4-fold (0.14 log units) above it; measured number inside the range.
By their numbers in this assay, from the lowest: compounds 4, 1 and 3 (each within the scatter of the next); then compound 2.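

In this assay, dipentylamino in place of 2-(dipropylamino)ethyl gives a 1.5-fold lower number from compound 3 to compound 4 (0.17 log units; within the scatter) at this position, so exchanging one amine side chain for the other produces no readable change. Compound 4 keeps the gain over the amine-free pentyl ether, with a 3.0-fold lower number from compound 2 to compound 4 (0.48 log units; beyond the scatter) as a modest step. It does not move away from the ethyl ether, with a 1.1-fold lower number from compound 1 to compound 4 (0.02 log units; within the scatter) inside the scatter.

As far as these compounds go, whether a piperidine or morpholine in place of the open-chain amine would shift the number remains open. No evidence here accounts for these steps.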